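A few compounds are considered here, and "the series" means these few. Any claim that something is new, unique, unknown or untested is made for them only; others in the source may bear on it.

Compounds measured:
compound 1 `CCCCCCNc1[nH]ccc2ncnc1-2` — 53%
compound 2 `CN(C)c1[nH]ccc2ncnc1-2` — 8%
compound 3 `[N-]=[N+]=Nc1[nH]ccc2ncnc1-2` — 20%

In a functional assay (Homo sapiens) for inhibition of Nucleic Acid, tested at 100 uM (a higher number here means more inhibition at the concentration tested (going by the name of the read-out), a lower number less inhibition), compound 3 gives 20%, the second highest of the three numbers. Its nearest neighbour is compound 2, whose 8% lies lower by a step beyond the scatter; the highest number belongs to compound 1 at 53%.

The step to compound 4 `CNc1[nH]ccc2ncnc1-2` is methylamino in place of azido on an aromatic carbon. Among the measured compounds shown here, only one measured step touches this position: a number 12 percentage points higher from compound 2 to compound 3 (beyond the scatter). That step joins the azido of compound 3 to dimethylamino, not to methylamino, so it bears on the present change only loosely. Compound 4 carries one hydrogen-bond donor, as compound 1 does, but a much shorter chain than the hexylamino of compound 1; compound 2, with no donor, sits lowest. For the measured compounds named here, the data give no step that pins down how much of the difference between compound 1 and compound 2 comes from the donor and how much from the chain.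

The step to compound 4 is therefore expected to be small, roughly a number 2 percentage points higher from compound 3 to compound 4 (within the scatter), possibly within the scatter. For compound 4 in this assay an inhibition of about 22% is estimated, with a range from 6% to 45%.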

Compound 4, a percentage reported as inhibition, at one concentration (the size of the read-out at that concentration, not a potency): 18%
The estimate for compound 4 lay 4 percentage points above the measured number; measured number inside the range.
By their numbers in this assay, from the lowest: compounds 2, 4 and 3 (each within the scatter of the next, the first and the last beyond it); then compound 1.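

In this assay, the swap on this aromatic carbon leaves the read-out where it was, a number 2 percentage points lower from compound 3 to compound 4 (within the scatter), so methylamino and azido cannot be told apart here, even though they differ in size and in hydrogen-bond donors. Trimming dimethylamino to methylamino likewise stays inside the noise, a number 10 percentage points higher from compound 2 to compound 4 (within the scatter), so compound 4 cannot be separated from either neighbour, although compound 2 and compound 3 are themselves separated by a step beyond the scatter. The chain is what matters among the new steps: a number 35 percentage points lower from compound 1 to compound 4 (beyond the scatter), which shows that, with the nitrogen hydrogen kept in both compounds, going from hexylamino to methylamino takes away most of the inhibition seen for compound 1.

Going by these compounds, what remains open is the shape of the chain-length trend, meaning whether ethylamino or butylamino would already give part of this gain and whether octylamino would extend it or lose it. On these data alone, it is also open whether the gain needs an unbroken alkyl chain, or whether a cyclohexylamino group or a hexyl chain ending in a hydroxyl or a carboxylic acid would keep it.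

Nothing measured alongside these numbers explains them.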